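Fluorine out, nitro in: a step toward compound 3

The compounds below may be only part of what the source reports. "The series", "measured", "known", "first", "only" and "open" are said of these compounds alone.

Compound 1 `Cc1ccc(Cn2cc(COc3ccc4c(=O)ccoc4c3)nn2)cc1` gives 10400 nM in a functional assay on SW480 cells (Homo sapiens) for cytotoxicity, read by MTT assay, with a stated time of 48 h; on this read-out higher numbers stand for weaker inhibition and lower numbers for stronger inhibition. Compound 2 `O=c1ccoc2cc(OCc3cn(Cc4cccc(F)c4)nn3)ccc12` reaches only the limit > 100000 nM in this assay, so its number is not known. The step of an at least 9.6-fold higher number from compound 1 to compound 2 (0.98 log units; beyond the scatter) thus placed compound 2 at the limit of > 100000 nM in this assay, at which 1 of the 2 values shown sits. Compound 3 `O=c1ccoc2cc(OCc3cn(Cc4ccc([N+](=O)[O-])cc4)nn3)ccc12` differs from compound 2 by 4-nitrophenyl in place of 3-fluorophenyl on a saturated chain carbon bound to an aromatic nitrogen. Within the data shown here, no measured step covers this change; the only known step concerns a different pair and ended at the ceiling of this assay. The expected step of an at least 1.2-fold lower number from compound 2 to compound 3 (0.09 log units; that floor lies within the scatter) is accordingly modest. Compound 3 is estimated at 80000 nM, within a range from 20000 nM to 300000 nM.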

Compound 3, half-maximal inhibitory concentration: 19300 nM
Compound 3: middle estimate off by 4.1-fold (0.62 log units), on the high side; measured number below the stated range.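

The new value shows that this position, on a saturated chain carbon bound to an aromatic nitrogen, can give a readable number in this assay with 4-nitrophenyl, unlike 3-fluorophenyl (an at least 5.1-fold lower number from compound 2 to compound 3 (0.71 log units; beyond the scatter)). Nitro in place of methyl leaves compound 1 and compound 3 within the scatter of each other (a 1.9-fold higher number from compound 1 to compound 3 (0.27 log units; within the scatter)). Compound 2 alone remains a limit: (the limit of > 100000 nM in this assay, at which 1 of the 3 values shown sits).

The step from compound 2 to compound 3 changes both the substituent and its ring position, so the contribution of each stays unresolved. From the compounds shown here alone, whether 4-fluorophenyl, or an amine or a carboxylic acid in place of the nitro, would give a readable number also stays open.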